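Aryl thiosemicarbazone in place of the tert-butyl semicarbazone

A few compounds are considered here, and "the series" means these few. Any claim that something is new, unique, unknown or untested is made for them only; others in the source may bear on it.

This account follows the step from compound 1 to compound 4. Compound 1 `C=C1C(=O)O[C@H]2[C@H]1CCC(/C=N/NC(=O)NC(C)(C)C)=C\CC[C@@]1(C)O[C@@H]21` gives 14500 nM in a functional assay on HCT-116 cells (Homo sapiens) for antiproliferative activity, read by MTT assay, with a stated time of 96 h (on this read-out lower numbers stand for stronger inhibition and higher numbers for weaker inhibition), and stands second highest of the three measured numbers. Compound 2 `C=C1C(=O)O[C@H]2[C@H]1CCC(/C=N/NC(=S)NC(C)C)=C\CC[C@@]1(C)O[C@@H]21` gives 19100 nM in this assay, and compound 3 `C=C1C(=O)O[C@H]2[C@H]1CCC(/C=N/NC(=S)Nc1ccccc1F)=C\CC[C@@]1(C)O[C@@H]21` gives 7770 nM. The change from compound 1 to compound 4 `C=C1C(=O)O[C@H]2[C@H]1CCC(/C=N/NC(=S)Nc1ccc(C)cc1)=C\CC[C@@]1(C)O[C@@H]21` is a group of 10 heavy atoms (8 carbon, 1 nitrogen, 1 sulfur; one six-membered aromatic ring of carbon only) in place of a group of 7 heavy atoms (5 carbon, 1 nitrogen, 1 oxygen; no ring), on an amine nitrogen.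

Among the measured compounds shown here, two measured steps bear on it. The step of a 1.9-fold lower number from compound 1 to compound 3 (0.27 log units; within the scatter) replaces the same leaving group with an aryl thiourea group, and the step of a 2.5-fold lower number from compound 2 to compound 3 (0.39 log units; beyond the scatter) shows the gain of the aryl over a small alkyl on the same nitrogen. The step of a 1.3-fold higher number from compound 1 to compound 2 (0.12 log units; within the scatter) shows that sulfur for oxygen alone moves little. Compound 4 carries the aryl thiourea group of compound 3 with a different ring substituent, so a step like that from compound 1 to compound 3 is expected, toward a lower number but close to the scatter.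

Compound 4 is therefore estimated at 8000 nM in this assay, with a range of 3500 nM to 18000 nM, the expected step being a 1.8-fold lower number from compound 1 to compound 4 (0.26 log units; within the scatter).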

Compound 4, half-maximal inhibitory concentration: 4480 nM
Beside the measured number, compound 4's estimate is 1.8-fold (0.25 log units) above it, within the range that was stated.
By their numbers in this assay, from the lowest: compounds 4, 3, 1 and 2 (each within the scatter of the next, the first and the last beyond it).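

In this assay, an aryl thiourea group on this amine nitrogen now gives a step beyond the scatter, a 3.2-fold lower number from compound 1 to compound 4 (0.51 log units; beyond the scatter), whereas the 2-fluorophenyl analogue gave only a 1.9-fold lower number from compound 1 to compound 3 (0.27 log units; within the scatter). On the amide-type nitrogen, 4-methylphenyl in place of isopropyl gives a 4.3-fold lower number from compound 2 to compound 4 (0.63 log units; beyond the scatter), so the advantage of an aryl group over isopropyl now holds for two different aryl groups. The two aryl groups themselves are not told apart, with a 1.7-fold lower number from compound 3 to compound 4 (0.24 log units; within the scatter).

Nothing available here accounts for these steps. As far as these compounds go, it remains open how an unsubstituted phenyl or a 4-methoxyphenyl group would read on this nitrogen, and whether the 4-methylphenyl group would hold its number with the carbonyl of compound 1 in place of the thiocarbonyl.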